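The source may hold more compounds than are shown below. What is called first, only, known or untested is meant among the compounds shown, and "the series" means these compounds.

Compound 1 `C#CCOc1ccc2c(=O)c(-c3cc(OC)c(OC)cc3OC)coc2c1` carries a propargyloxy group on the shared core. In a functional assay on HCT-116 cells (Homo sapiens) for antiproliferative activity, read by MTT assay, with a stated time of 24 h (on this read-out higher numbers stand for weaker inhibition and lower numbers for stronger inhibition), compound 1 gives 8050 nM, the highest of the three numbers measured. Its two measured neighbours swap that group for a benzyloxy group: compound 2 `COc1cc(OC)c(-c2coc3cc(OCc4ccccc4C(F)(F)F)ccc3c2=O)cc1OC` gives 4760 nM in this assay, and compound 3 `COc1cc(OC)c(-c2coc3cc(OCc4ccccc4Cl)ccc3c2=O)cc1OC` gives 2450 nM. The change a 1.7-fold lower number from compound 1 to compound 2 (0.23 log units; within the scatter) stays within the scatter, while a 3.3-fold lower number from compound 1 to compound 3 (0.52 log units; beyond the scatter) is a modest change beyond it. Between the two aryl compounds, a 1.9-fold lower number from compound 2 to compound 3 (0.29 log units; within the scatter) is within the scatter, so the two measured aryl groups cannot be told apart.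

Compound 4 `COc1cc(OC)c(-c2coc3cc(OCc4cccc(Br)c4)ccc3c2=O)cc1OC` has not yet been measured in this assay. It differs from compound 1 in one place: 3-bromophenyl in place of ethynyl on a saturated chain carbon bound to an oxygen on an aromatic ring. The two steps that bear on this change are the two that replace ethynyl with a substituted phenyl on a saturated chain carbon bound to an oxygen on an aromatic ring, and both moved the number downward, one within and one beyond the scatter. A lower number for compound 4 is therefore expected, of modest size, with the step of a 2.5-fold lower number from compound 1 to compound 4 (0.40 log units; beyond the scatter) as the estimate. Compound 4 is estimated to give 3200 nM in this assay, most likely between 1500 nM and 7000 nM.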

Compound 4, half-maximal inhibitory concentration: 1200 nM
Compound 4: the middle estimate sits 2.7-fold (0.43 log units) above what was measured; the whole stated range lies above it.
By their numbers in this assay, from the lowest: compound 4; then compounds 3, 2 and 1 (each within the scatter of the next, the first and the last beyond it).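

The step of a 6.7-fold lower number from compound 1 to compound 4 (0.83 log units; beyond the scatter) is the largest seen so far at this position, so a substituted phenyl in place of ethynyl on the saturated chain carbon can lower the number well beyond the scatter. It also shows that the choice of aryl group counts, which compounds 2 and 3 could not show, since the steps of a 2.0-fold lower number from compound 3 to compound 4 (0.31 log units; beyond the scatter) and a 4.0-fold lower number from compound 2 to compound 4 (0.60 log units; beyond the scatter) both lie beyond the scatter. In this assay compound 4 therefore has the lowest number of the four, and 3-bromophenyl is the only one of the three aryl groups set apart from both of the others.

From the compounds shown here alone, the groups 3-bromophenyl and 2-chlorophenyl differ in both the halogen and its place on the ring, so these two factors remain unseparated, and how an unsubstituted phenyl, or a phenyl bearing an amine or a carboxylic acid, would read remains open. No evidence is available that bears on what lies behind these differences.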